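The source may report more compounds than this note shows. Statements on the series, on what has been measured and on what is new or still open speak of the compounds shown alone.

Working notes on the series. In an assay on isolated protein for inhibition of Amine oxidase [flavin-containing] B (Homo sapiens), read by fluorescence, with stated times of 15 min and 20 min (a lower number here means a stronger inhibitor, a higher number a weaker inhibitor), compound 2, `O=C(CN1CCCCC1)N1N=C(c2ccccc2)CC1c1ccccc1O`, gives 50600 nM; compound 1, `O=C(CBr)N1N=C(c2ccc(F)cc2)CC1c1ccccc1O`, gives 52900 nM in this assay, and the two numbers lie within the scatter of each other, so neither is set apart. Compound 3, `O=C(CN1CCCCC1)N1N=C(c2ccc(F)cc2)CC1c1ccccc1O`, is not yet measured in this assay. It differs from compound 2 by fluoro in place of hydrogen on an aromatic carbon. Going by the values given here, no measured pair shows this change on its own here. The expectation for the step from compound 2 to compound 3 is a 1.1-fold lower number from compound 2 to compound 3 (0.05 log units; within the scatter), that is none beyond the scatter, given that compound 1 with its fluoro gives 52900 nM. Compound 3 is therefore estimated at 45000 nM, within a range from 20000 nM to 100000 nM.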

Compound 3, half-maximal inhibitory concentration: 47400 nM
For compound 3 the middle estimate is 1.1-fold (0.02 log units) below the measured one; low and high end bracket the measured number.
By their numbers in this assay, from the lowest: compounds 3, 2 and 1 (each within the scatter of the next).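

In this assay, phenyl to 4-fluorophenyl now has a single-change reading, a 1.1-fold lower number from compound 2 to compound 3 (0.03 log units; within the scatter), so fluoro at this position, para to a large group, is not set apart from hydrogen. The side chain also has its first single-change reading, a 1.1-fold lower number from compound 1 to compound 3 (0.05 log units; within the scatter), which does not set piperidin-1-yl apart from bromo on the saturated chain carbon bound to a carbonyl carbon. Nothing available accounts for either result. Still open, as far as these compounds go, is whether chloro or methoxy on this aromatic carbon, or morpholin-4-yl or dimethylamino on the chain carbon, would give a step beyond the scatter.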